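From compound 3 to compound 4: a smaller sulfonyl substituent

This account rests on a few compounds, and the source may have more. Where it says the series, first, only, none or still open, it means among the compounds named here.

In an ADME assay on a cell-free system (plasma, Mus musculus) (on this read-out lower numbers stand for a smaller free fraction and higher numbers for a larger free fraction), compound 3 (`Cc1ccc(S(=O)(=O)N2CCCCC2C)cc1C#Cc1cc(Cl)ccc1OCC(=O)O`) is reported as "not determined" (no result reported) and so offers no single number as a starting point. Among the measured compounds shown here, only two close analogues carry numbers. In this assay compound 1 (`Cc1ccc(S(=O)(=O)NC(C)C)cc1C#Cc1cc(Cl)ccc1OCC(=O)O`) gives 0.01 and compound 2 (`CC(C)c1ccc(S(C)(=O)=O)cc1C#Cc1cc(Cl)ccc1OCC(=O)O`) gives 0.013 as its reading, two values within the scatter of each other.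

Compound 4 (`Cc1ccc(S(C)(=O)=O)cc1C#Cc1cc(Cl)ccc1OCC(=O)O`) carries methyl in place of 2-methylpiperidin-1-yl on a sulfonyl sulfur. The size of this step cannot be read from the data, since one end of it has no number. The working expectation is therefore set against the measured pair: no shift beyond the scatter in this assay is expected, with at most a slight lean toward a larger free fraction. This rests on compound 1 at 0.01 and on compound 2 at 0.013 as the only reference points. In this assay compound 4 is estimated at 0.02 (expected range 0.008 to 0.05).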

Compound 4, unbound fraction: 0.027
Beside the measured number, compound 4's estimate is 1.4-fold (0.13 log units) below it; measured number inside the range.
By their numbers in this assay, from the lowest: compounds 1 and 2 (each within the scatter of the next); then compound 4.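

In this assay two single changes now register beyond the scatter: a 2.7-fold higher number from compound 1 to compound 4 (0.43 log units; beyond the scatter) with methyl in place of isopropylamino on a sulfonyl sulfur, and a 2.1-fold higher number from compound 2 to compound 4 (0.32 log units; beyond the scatter) with methyl in place of isopropyl on an aromatic carbon. The read-out therefore responds at both places, modestly and toward a larger free fraction in each case, which compound 1 and compound 2 could not show on their own. Compound 3 has no number, so the change from 2-methylpiperidin-1-yl to methyl itself cannot be read.

Nothing measured on these compounds accounts for either step. Still open, on these data alone, is how the free fraction would respond to a sulfonyl substituent carrying an amine or a hydroxyl group, or to a longer chain on the aromatic carbon.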